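Chain Length at the Amide of a Gastric Cancer Cell Series

The source may report more compounds than this note shows. Statements on the series, on what has been measured and on what is new or still open speak of the compounds shown alone.

Measured in a functional assay on MKN-45 cells (Homo sapiens) for antiproliferative activity, read by MTT assay, with a stated time of 72 h, tested at 10 uM; a higher number here means more inhibition at the concentration tested (going by the name of the read-out), a lower number less inhibition:
compound 1 `CC(=O)Nc1cc(Oc2ccc(Nc3nccc4[nH]cc(-c5ccc(F)cc5)c(=O)c34)cc2F)ccn1`: 77.1%
compound 2 `CCC(=O)Nc1cc(Oc2ccc(Nc3nccc4[nH]cc(-c5ccc(F)cc5)c(=O)c34)cc2F)ccn1`: 92.1%

Compound 2 stands highest of the two numbers; its nearest neighbour is compound 1, whose value lies beyond the scatter below it. Within the data shown here, the single measured step that bears on the chain is a number 15 percentage points higher from compound 1 to compound 2 (beyond the scatter), a modest gain on lengthening the acyl group by one carbon.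

Compound 3 `CCCCC(=O)Nc1cc(Oc2ccc(Nc3nccc4[nH]cc(-c5ccc(F)cc5)c(=O)c34)cc2F)ccn1` carries the same change taken further: ethyl in place of hydrogen on a saturated chain carbon, two bonds along the chain from a carbonyl carbon. Among the measured compounds shown here, only one step speaks to chain extension, and it was modest; compound 2 already sits close to the top of the scale in this assay, so little further gain is possible. Compound 3 is therefore expected to give about 90%, within 75% to 98%, meaning a step of a number 2.1 percentage points lower from compound 2 to compound 3 (within the scatter) that is expected to stay within the scatter.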

Compound 3, a percentage reported as inhibition, at one concentration (the size of the read-out at that concentration, not a potency): 62.7%
Beside the measured number, compound 3's estimate is 27.3 percentage points above it; the measured number lies below the stated range.
By their numbers in this assay, from the lowest: compound 3; then compound 1; then compound 2.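

In this assay, this position does not reward chain length steadily: replacing hydrogen with ethyl on the saturated chain carbon, two bonds along the chain from a carbonyl carbon, gives a number 29.4 percentage points lower from compound 2 to compound 3 (beyond the scatter), reversing the gain seen on the first extension. The longer chain also falls short of the shortest one, with a number 14.4 percentage points lower from compound 1 to compound 3 (beyond the scatter), so among these three compounds the response rises and then falls, peaking at compound 2. No measurement here accounts for this reversal.

The compounds shown leave open where between compound 2 and compound 3 the decline sets in, which a propyl group on the carbonyl carbon could help to place. They also leave open whether a longer chain, a branched isopropyl group or a chain ending in an amine would continue the decline.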